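A few compounds are considered here, and "the series" means these few. Any claim that something is new, unique, unknown or untested is made for them only; others in the source may bear on it.

Compound 3, with structure `COc1cc(-c2nn(-c3cccc(NC(=O)c4ccc(Cl)c(C(F)(F)F)c4)c3)cc2-c2ccncc2)ccc1Cl`, is known in a functional assay on OVCAR-3 cells (Homo sapiens) for inhibition, read by sulforhodamine B assay, with a stated time of 48 h (a lower number here means that less compound is tolerated, a higher number that more compound is tolerated), only as a limit, > 32500 nM. Compound 1, `COc1cc(-c2nn(-c3cccc(NC(=O)c4cccc(C(F)(F)F)c4)c3)cc2-c2ccncc2)ccc1Cl`, sits at a limit of > 50000 nM in this assay. Compound 2, `COc1cc(-c2nn(-c3cccc(NC(=O)Nc4ccc(Cl)c(Cl)c4)c3)cc2-c2ccncc2)ccc1Cl`, likewise sits at a limit of > 50000 nM. Every measured step among these three is therefore unreadable: a step that the two limits leave unreadable from compound 1 to compound 2, a step that the two limits leave unreadable from compound 1 to compound 3 and a step that the two limits leave unreadable from compound 2 to compound 3. Compound 4, `COc1cc(-c2nn(-c3cccc(NC(=O)Nc4ccc(Cl)c(C(F)(F)F)c4)c3)cc2-c2ccncc2)ccc1Cl`, differs from compound 3 by (4-chloro-3-(trifluoromethyl)phenyl)amino in place of 4-chloro-3-(trifluoromethyl)phenyl on a carbonyl carbon. Among the measured compounds shown here, the closest precedent is the urea-for-amide exchange a step that the two limits leave unreadable from compound 2 to compound 3, which gave no readable size. With all three values at limits the limit of > 32500 nM in this assay, at which 1 of the 3 values shown sits (the limit of > 50000 nM in this assay, at which 2 of the 3 values shown sit), no step beyond the scatter can be expected for compound 4, whose value in this assay is estimated at 60000 nM with a range from 30000 nM to 120000 nM. The expected step is a step that the limit leaves unreadable from compound 3 to compound 4.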

Compound 4, concentration lethal to 50% of the cells: > 32500 nM
Compound 4 was reported as a limit; the forecaster's own chance of this, stated with the estimate: 85%; the middle value lies beyond the limit too.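

Compound 4 stands at a limit, > 32500 nM, in this assay, and its steps from compound 1, compound 2 and compound 3, all limits too, cannot be read. The compounds shown leave open whether the urea-for-amide exchange or any other change among them shifts the value at all.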